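Side-chain variation on the piperidine amide series, working notes

The source may report more compounds than this note shows. Statements on the series, on what has been measured and on what is new or still open speak of the compounds shown alone.

Measured so far:
compound 1, `Cn1ncc(Cl)c1-c1cc(C(=O)N[C@@H]2CN[C@H](CCCO)C[C@H]2c2ccc(Cl)c(Cl)c2)oc1Cl`, 2.56 nM
compound 2, `CN(C)CC[C@@H]1C[C@@H](c2ccc(Cl)c(Cl)c2)[C@H](NC(=O)c2cc(-c3c(Cl)cnn3C)c(Cl)o2)CN1`, 3.4 nM

Both numbers come from an assay for inhibition of RAC-alpha serine/threonine-protein kinase (Homo sapiens), read by HTRF, with a stated time of 1 h; on this read-out higher numbers stand for weaker inhibition and lower numbers for stronger inhibition. Compound 2 holds the higher of the two numbers shown, but its nearest neighbour, compound 1, differs by a 1.3-fold higher number from compound 1 to compound 2 (0.12 log units; within the scatter), so the two compounds cannot be told apart on these data. Among the compounds with values here, the one measured step therefore says that swapping the terminal group on this saturated side chain, hydroxymethyl for dimethylamino, leaves the read-out essentially unchanged.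

Compound 3, `Cn1ncc(Cl)c1-c1cc(C(=O)N[C@@H]2CN[C@H](CC(=O)NCCO)C[C@H]2c2ccc(Cl)c(Cl)c2)oc1Cl`, is not yet measured. Against compound 2 the change is (2-hydroxyethyl)carbamoyl in place of (dimethylamino)methyl on a saturated chain carbon bound to a saturated ring carbon. It keeps the shared core and the side-chain attachment point and again exchanges only what sits on the chain, as in the measured step. Within the data shown here, only the step from compound 1 to compound 2 bears on it, and that step stayed within the scatter. The expectation for compound 3 in this assay is therefore a step of about a 1.2-fold higher number from compound 2 to compound 3 (0.07 log units; within the scatter), that is, no clear movement beyond the scatter in either direction. Compound 3 is estimated at 4 nM, with a range from 1.5 nM to 12 nM.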

Compound 3, half-maximal inhibitory concentration: 1.41 nM
Compound 3: the middle estimate sits 2.8-fold (0.45 log units) above what was measured; measured number outside the range, below it.
By their numbers in this assay, from the lowest: compounds 3, 1 and 2 (each within the scatter of the next, the first and the last beyond it).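

Working notes, side-chain position: in this assay, the place on a saturated chain carbon bound to a saturated ring carbon now gives its first step beyond the scatter, with (2-hydroxyethyl)carbamoyl in place of (dimethylamino)methyl producing a 2.4-fold lower number from compound 2 to compound 3 (0.38 log units; beyond the scatter) as a modest change. The same entering group in place of 2-hydroxyethyl gives a 1.8-fold lower number from compound 1 to compound 3 (0.26 log units; within the scatter) and stays within the scatter, so the separation holds against only one of the two earlier side chains, and compound 1 and compound 3 cannot be told apart. The position therefore accepts the carbonyl-containing chain without any weakening on this read-out, but no line of measured data on these compounds accounts for the step.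

The compounds shown leave open whether the step follows the carbonyl and amide hydrogen of the (2-hydroxyethyl)carbamoyl group or its terminal hydroxyl, which a plain primary amide or a 2-methoxyethyl amide at this place would separate. They also leave open how a carboxylic acid or a primary amine on the same chain would read.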